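Acyl swap on the ring nitrogen of compound 2

The source may report more compounds than this note shows. Statements on the series, on what has been measured and on what is new or still open speak of the compounds shown alone.

In a functional assay on NUGC-3 cells (Homo sapiens) for cytotoxicity, read by sulforhodamine B assay, with a stated time of 72 h (a lower number here means a stronger inhibitor of growth, a higher number a weaker inhibitor of growth), compound 2 `O=C(Nc1cc(C(F)(F)F)cc(C(F)(F)F)c1)C1CCc2ccccc2N1C(=O)c1ccc(Cl)cc1` gives 1660 nM, compound 1 `O=C(Nc1ccccc1C(F)(F)F)C1CCc2ccccc2N1C(=O)c1ccccc1` gives 8120 nM, and compound 3 `O=C(Nc1ccccc1C(F)(F)F)C1CCc2ccccc2N1` gives 39300 nM. The number for compound 2 is the lowest of the three, and its gaps to compound 1 and to compound 3 both lie outside the usual scatter. Compound 4 `CCCCCCCCC(=O)N1c2ccccc2CCC1C(=O)Nc1cc(C(F)(F)F)cc(C(F)(F)F)c1` differs from compound 2 by octyl in place of 4-chlorophenyl on a carbonyl carbon. For the measured compounds named here, the only measured step bearing on the acyl group on that nitrogen is a 4.8-fold higher number from compound 1 to compound 3 (0.68 log units; beyond the scatter), which removes the acyl group altogether rather than exchanging one for another; no measured pair swaps an aryl acyl for an alkyl acyl, so the size of the present change is unsupported. The loss seen there shows the acyl group counts, while a mere exchange may cost less. Compound 4 is therefore expected to give roughly 3200 nM, within 800 nM to 13000 nM. The expected step is a 1.9-fold higher number from compound 2 to compound 4 (0.29 log units; within the scatter), a modest rise.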

Compound 4, concentration for 50% growth inhibition: 2230 nM
Estimate against measurement, compound 4: 1.4-fold (0.16 log units) above; measured number inside the range.
By their numbers in this assay, from the lowest: compounds 2 and 4 (each within the scatter of the next); then compound 1; then compound 3.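

In this assay, octyl in place of 4-chlorophenyl on a carbonyl carbon gives a 1.3-fold higher number from compound 2 to compound 4 (0.13 log units; within the scatter), so for this pair the acyl group need not carry a ring. For the compounds shown here, this is the first exchange of one acyl group for another; the earlier step showed only the removal of the group. No measured data explain this result.

As far as these compounds go, whether a longer chain, or an acyl group ending in an amine or a carboxylic acid, would behave the same stays open. Also open, from the compounds shown here alone, is whether removing the acyl group from compound 2 would repeat a 4.8-fold higher number from compound 1 to compound 3 (0.68 log units; beyond the scatter).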